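From 4-bromophenyl to 3-fluorophenyl on a shared core

The source may report more compounds than this note shows. Statements on the series, on what has been measured and on what is new or still open speak of the compounds shown alone.

- Compound 1 `COc1ccccc1NC(=S)N/N=C/c1ccc2ccccc2n1`: > 100000 nM, a limit
- Compound 2 `S=C(N/N=C/c1ccc2ccccc2n1)Nc1ccccc1Br`: > 100000 nM, a limit
- Compound 3 `S=C(N/N=C/c1ccc2ccccc2n1)Nc1ccc(Br)cc1`: 54400 nM

All three results come from a functional assay on HT-29 cells (Homo sapiens) for antiproliferative activity, read by sulforhodamine B assay, with a stated time of 72 h; a lower number here means a stronger inhibitor, a higher number a weaker inhibitor. Going by the values given here, compound 3, at 54400 nM, is the only one with an actual number. Compound 1 and compound 2 rest at the limit of > 100000 nM in this assay, at which 2 of the 3 values shown sit.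

Compound 4 `Fc1cccc(NC(=S)N/N=C/c2ccc3ccccc3n2)c1` carries 3-fluorophenyl in place of 4-bromophenyl on an amide-type nitrogen. Two measured steps change this same group: an at least 1.8-fold lower number from compound 1 to compound 3 (0.26 log units; that floor lies within the scatter) and an at least 1.8-fold lower number from compound 2 to compound 3 (0.26 log units; that floor lies within the scatter). Among the compounds with values here, both give only a floor, so neither fixes a size, and no measured compound carries 3-fluorophenyl. A small expected move toward a weaker inhibitor follows, with the limit within reach. The expected change is a 1.3-fold higher number from compound 3 to compound 4 (0.11 log units; within the scatter). For compound 4 the estimate is 70000 nM, with an expected range of 25000 nM to 100000 nM.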

Compound 4, half-maximal inhibitory concentration: 74700 nM
Beside the measured number, compound 4's estimate is 1.1-fold (0.03 log units) below it; measured number inside the range.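

In this assay this swap gives a 1.4-fold higher number from compound 3 to compound 4 (0.14 log units; within the scatter) and so a second real number at this nitrogen, with no difference that can be read between the two groups. A readable number here therefore does not need a bromine on the phenyl ring. Compound 1 and compound 2 rest on limits, so the steps to them are only floors: an at least 1.3-fold lower number from compound 1 to compound 4 (0.12 log units; that floor lies within the scatter) and an at least 1.3-fold lower number from compound 2 to compound 4 (0.12 log units; that floor lies within the scatter) leave the true size of both gaps unsettled.

Going by these compounds, whether an amine or a carboxylic acid on this phenyl ring would give a clearly lower number stays open. So does the outcome for a longer chain in place of the ring.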